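The source may report more compounds than this note shows. Statements on the series, on what has been measured and on what is new or still open speak of the compounds shown alone.

Of the compounds shown here, two have been measured in a functional assay on HepG2 cells (Homo sapiens) for cytotoxicity, read by MTT assay, with a stated time of 72 h; a higher number here means a weaker inhibitor, a lower number a stronger inhibitor. Compound 1 `COc1c(OCCCCN2CCN(C)CC2)cc(O)c2c(=O)cc(-c3ccc(C(F)(F)F)cc3)oc12` gives 2400 nM in this assay. Compound 2 `CN1CCN(CCCCOc2c(OCc3ccc(C#N)cc3)cc(O)c3c(=O)cc(-c4ccccc4)oc23)CC1` gives 590 nM in this assay, the lower of the two numbers, with the gap to compound 1 beyond the usual scatter. Compound 3 `CN1CCN(CCCCOc2c(OCc3nc4ccccc4o3)cc(O)c3c(=O)cc(-c4ccccc4)oc23)CC1` has not been measured; it differs from compound 2 by 1,3-benzoxazol-2-yl in place of 4-cyanophenyl on a saturated chain carbon bound to an oxygen on an aromatic ring. For the measured compounds named here, no measured pair shows this change, so no step beyond the scatter is expected in either direction; the step from a 1.3-fold higher number from compound 2 to compound 3 (0.10 log units; within the scatter) is the working expectation. In this assay compound 3 is expected to give about 750 nM, within a range of 300 nM to 2000 nM.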

Compound 3, half-maximal inhibitory concentration: 4110 nM
Estimate against measurement, compound 3: 5.5-fold (0.74 log units) below; the measured number lies above the stated range.
By their numbers in this assay, from the lowest: compound 2; then compounds 1 and 3 (each within the scatter of the next).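

In this assay, the group on a saturated chain carbon bound to an oxygen on an aromatic ring clearly affects the number: 1,3-benzoxazol-2-yl in place of 4-cyanophenyl gives a 7.0-fold higher number from compound 2 to compound 3 (0.84 log units; beyond the scatter), a step beyond the scatter. This position is therefore sensitive to an exchange of one aromatic group for another, and in this pair the lower number belongs to 4-cyanophenyl. No available evidence bears on the cause of this step. Still open, going by these compounds, is how a pyridine ring, or a carboxylic acid or an amine on the phenyl ring, would read at this place.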